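From Compound 2 to Compound 4: A Halogen Exchange

This account rests on a few compounds, and the source may have more. Where it says the series, first, only, none or still open, it means among the compounds named here.

Measured compounds:
compound 1 `O=C(CSc1ncccn1)N/N=c1/scc(-c2ccc(F)cc2)n1-c1ccccc1`: 32.2%
compound 2 `Cc1nnc(SCC(=O)N/N=c2/scc(-c3ccc(F)cc3)n2-c2ccccc2)s1`: 26.5%
compound 3 `O=C(CSc1nnnn1-c1ccccc1)N/N=c1/scc(-c2ccc(F)cc2)n1-c1ccccc1`: 30.6%

In a functional assay on C6 cells (Rattus norvegicus) for cytotoxicity, read by MTT assay, with a stated time of 24 h, tested at 200 ug/mL (on this read-out higher numbers stand for a weaker effect at the one concentration tested and lower numbers for a stronger effect), compound 2 gives 26.5%, the smallest of the three numbers, though within the usual scatter of both others: compound 3 with 30.6% is nearest, and compound 1 with 32.2% is furthest. The steps of a number 5.7 percentage points lower from compound 1 to compound 2 (within the scatter), a number 1.6 percentage points lower from compound 1 to compound 3 (within the scatter) and a number 4.1 percentage points higher from compound 2 to compound 3 (within the scatter) all vary the group on the sulfur and leave the 4-fluorophenyl untouched; each stayed within the scatter.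

Compound 4 `Cc1nnc(SCC(=O)N/N=c2/scc(-c3ccc(Cl)cc3)n2-c2ccccc2)s1` differs from compound 2 as follows: chloro in place of fluoro on an aromatic carbon. Within the data shown here, no measured step touches this position, so there is no evidence for a shift beyond the scatter in this assay. Compound 4 is therefore expected to move only by a number 1.5 percentage points higher from compound 2 to compound 4 (within the scatter). The estimate for compound 4 is 28%, ranging from 16% to 40%.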

Compound 4, a percentage reported as activity, at one concentration (the size of the read-out at that concentration, not a potency): 29%
Compound 4: middle estimate off by 1 percentage points, on the low side; measured number inside the range.
By their numbers in this assay, from the lowest: compounds 2, 4, 3 and 1 (each within the scatter of the next).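

Among these compounds, compound 4 supplies the only step that touches this position: in this assay, 4-chlorophenyl in place of 4-fluorophenyl gives a number 2.5 percentage points higher from compound 2 to compound 4 (within the scatter), with 5-methyl-1,3,4-thiadiazol-2-yl on the sulfur. So this halogen exchange, like the changes on the sulfur, stays within the scatter. Nothing available explains the size of this step.

As far as these compounds go, whether an amine or a carboxylic acid at this position would also stay within the scatter remains open. So does the effect of this exchange with pyrimidin-2-yl or 1-phenyl-1H-tetrazol-5-yl on the sulfur.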